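Iodo in place of thiophen-3-yl on the shared core

This account rests on a few compounds, and the source may have more. Where it says the series, first, only, none or still open, it means among the compounds named here.

Compound 1 `Nc1nc(N)c2c(-c3ccsc3)cn([C@@H]3O[C@H](CO)[C@@H](O)[C@H]3O)c2n1`, compound 2 `Cc1nc(N)c2c(-c3ccsc3)cn([C@@H]3O[C@H](CO)[C@@H](O)[C@H]3O)c2n1` and compound 3 `CNc1ncnc2c1c(-c1cc3ccccc3o1)cn2[C@@H]1O[C@H](CO)[C@@H](O)[C@H]1O` share the same sugar-bearing core. In a functional assay on K562 cells (Homo sapiens), read by MTT assay, with a stated time of 72 h (on this read-out lower numbers stand for stronger inhibition and higher numbers for weaker inhibition), compound 1 gives only a limit, > 20000 nM. Compound 2 also gives only a limit in this assay, > 20000 nM. Compound 3 likewise gives only a limit, > 20000 nM. Thus (the limit of > 20000 nM in this assay, at which 3 of the 3 values shown sit). Among the compounds with values here, the one step, a step that the two limits leave unreadable from compound 1 to compound 2, methyl in place of amino on an aromatic carbon, cannot be read. Compound 4 `Cc1nc(N)c2c(I)cn([C@@H]3O[C@H](CO)[C@@H](O)[C@H]3O)c2n1` differs from compound 2 by iodo in place of thiophen-3-yl on an aromatic carbon. Within the data shown here, no measured step covers this change. Compound 4 is therefore expected to remain at the limit, with the estimated step that the limit leaves unreadable from compound 2 to compound 4 unreadable. The estimate for compound 4 is 30000 nM, within 10000 nM to 100000 nM.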

Compound 4, half-maximal inhibitory concentration: 5120 nM
Beside the measured number, compound 4's estimate is 5.9-fold (0.77 log units) above it, and the stated range ends above it.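

Within the data shown here, compound 4 is the first compound with a number rather than a limit in this assay, so this position on the five-membered aromatic ring can shift the read-out. Iodo in place of thiophen-3-yl gives an at least 3.9-fold lower number from compound 2 to compound 4 (0.59 log units; beyond the scatter). The other compounds all remain at one limit: the limit of > 20000 nM in this assay, at which 3 of the 4 values shown sit.

Going by these compounds, whether bromo, chloro or an amine at this position would give a similar number remains open. On these data alone, it is also open whether amino in place of methyl would keep the number of compound 4.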